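A Smaller Pyridylmethyl Group in Place of a Fused Ring

The source may report more compounds than this note shows. Statements on the series, on what has been measured and on what is new or still open speak of the compounds shown alone.

Compound 2 `Fc1cc(-n2nnc(-c3ccccn3)n2)cc(-n2ccc3ccncc32)c1` gives the lowest of the two numbers seen so far in a functional assay for antagonist activity at metabotropic glutamate receptor 5 (Homo sapiens); a lower number here means a stronger inhibitor, a higher number a weaker inhibitor: it shows 16 nM. Compound 1 `c1ccc(-c2nnn(-c3ccccc3Oc3cccnc3)n2)nc1` lies far weaker, giving 1580 nM in this assay. Compound 3 `Fc1cc(Cc2cccnc2)cc(-n2nnc(-c3ccccn3)n2)c1` is not yet measured; it differs from compound 2 by a group of 7 heavy atoms (6 carbon, 1 nitrogen; one six-membered aromatic ring with 1 hetero atom) in place of a group of 9 heavy atoms (7 carbon, 2 nitrogen; one five-membered aromatic ring with 1 hetero atom, one six-membered aromatic ring with 1 hetero atom), on an aromatic carbon. Within the data shown here, no comparable step between measured compounds exists, so the expected step from compound 2 to compound 3 rests only on the change itself, and a weakening of roughly a 9.4-fold higher number from compound 2 to compound 3 (0.97 log units; beyond the scatter) in this assay is expected. Compound 3 is therefore estimated at 150 nM, within a range of 40 nM to 600 nM.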

Compound 3, half-maximal inhibitory concentration: 17 nM
Compound 3: middle estimate off by 8.8-fold (0.95 log units), on the high side; the whole stated range lies above it.
By their numbers in this assay, from the lowest: compounds 2 and 3 (each within the scatter of the next); then compound 1.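

On this aromatic carbon, the smaller (pyridin-3-yl)methyl group takes the place of the fused two-ring group with no change that can be told apart in this assay, giving a 1.1-fold higher number from compound 2 to compound 3 (0.03 log units; within the scatter) and staying within the scatter. The fused five-membered ring is thus not required for a low number in this pair of compounds. Nothing measured here accounts for the match. Still open, on these data alone, is whether the ring nitrogen of the new group matters, which a plain benzyl group would test. A longer chain, such as a two-carbon link to the same pyridine ring, would likewise test the length of the link.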